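Removing a fluorine from the pyrazolone aryl ring

The compounds below may be only part of what the source reports. "The series", "measured", "known", "first", "only" and "open" are said of these compounds alone.

Compound 2 is `O=C(Nc1ccc(Oc2ncnc3ccsc23)c(F)c1)c1nn(-c2ccc(F)cc2)ccc1=O`. In a functional assay on HepG2 cells (Homo sapiens) for cytotoxicity, read by MTT assay, with a stated time of 72 h (on this read-out lower numbers stand for stronger inhibition and higher numbers for weaker inhibition), compound 2 gives 9160 nM. For the measured compounds named here, its only companion is compound 1, `Cc1cc(=O)n(-c2ccc(F)cc2)nc1C(=O)Nc1ccc(Oc2ncnc3sccc23)cc1`, which in this assay gives 6460 nM; the two numbers lie within the usual scatter of one another, so neither can be called the more active.

Compound 3 is `O=C(Nc1ccc(Oc2ncnc3ccsc23)c(F)c1)c1nn(-c2ccccc2)ccc1=O`. It differs from compound 2 in one place: hydrogen in place of fluoro on an aromatic carbon. Read one bond further out, the change is from 4-fluorophenyl to phenyl; the place is on an aromatic carbon of a six-membered aromatic ring of carbon only, para to a large group.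

Going by the values given here, no pair of measured compounds shows this change, so there is no measured step to lean on. A single fluorine leaving a position para to a large group is among the smallest changes one can make, and the expectation is a step no larger than the scatter, if anything toward a slightly higher number. The step from compound 2 to compound 3 in this assay is therefore expected to be a 1.1-fold higher number from compound 2 to compound 3 (0.04 log units; within the scatter). For compound 3 the estimate in this assay is 10000 nM, with a plausible range from 4500 nM to 25000 nM.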

Compound 3, half-maximal inhibitory concentration: 13500 nM
Beside the measured number, compound 3's estimate is 1.4-fold (0.13 log units) below it, within the range that was stated.
By their numbers in this assay, from the lowest: compounds 1, 2 and 3 (each within the scatter of the next, the first and the last beyond it).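

In this assay, for the compounds shown here, the exchange of 4-fluorophenyl for phenyl gives a 1.5-fold higher number from compound 2 to compound 3 (0.17 log units; within the scatter) and is the first measured step at this place on the ring, which until now could only be estimated. It shows that, in this pair, the fluoro on this aromatic carbon can be replaced by hydrogen without a step beyond the usual scatter of repeated measurements, so this one fluorine does not visibly set the level of cytotoxicity in these cells. No separate measurement bears on this result, so the pair gives the size of the step and nothing about what lies behind it.

The compounds shown leave open whether a group other than hydrogen or fluoro on this same aromatic carbon, such as chloro, methoxy, an amine or a carboxylic acid, would give a step beyond the scatter. They also leave open whether the same exchange of fluoro for hydrogen would give a step of similar size on the core of compound 1, since a single pair cannot show whether this result carries over to another core.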